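Removing a Trifluoromethyl Group from the Pendant Aryl Ring

The source may hold more compounds than are shown below. What is called first, only, known or untested is meant among the compounds shown, and "the series" means these compounds.

Measured so far in a functional assay on BJAB cells (Homo sapiens) for antiproliferative activity, with a stated time of 4 days; a higher number here means that more compound is needed for the effect, a lower number that less compound is needed:
Compound 1, `COc1cc(-c2c(C)nn(-c3nc(-c4ccc(Cl)c(Cl)c4)c(SC(C)C)s3)c2C(=O)O)cc(C(F)(F)F)c1`, gives 1380 nM
Compound 2, `COc1cccc(-c2c(C)nn(-c3nc(-c4ccc(Cl)c(Cl)c4)c(SC(C)C)s3)c2C(=O)O)c1`, gives 14000 nM
Compound 3, `Cc1nn(-c2nc(-c3ccc(Cl)c(Cl)c3)c(SC(C)C)s2)c(C(=O)O)c1-c1ccccc1C(F)(F)F`, gives 5200 nM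

The three compounds share one core and differ only in the aryl ring attached to it. The difference between compound 1 and compound 2 is hydrogen in place of trifluoromethyl on an aromatic carbon, and this change gave a 10-fold higher number from compound 1 to compound 2 (1.01 log units; beyond the scatter). The difference between compound 1 and compound 3 is 2-(trifluoromethyl)phenyl in place of 3-methoxy-5-(trifluoromethyl)phenyl on an aromatic carbon, which gave a 3.8-fold higher number from compound 1 to compound 3 (0.58 log units; beyond the scatter). Between compound 2 and compound 3 the step was a 2.7-fold lower number from compound 2 to compound 3 (0.43 log units; beyond the scatter).

Compound 4, `Cc1nn(-c2nc(-c3ccc(Cl)c(Cl)c3)c(SC(C)C)s2)c(C(=O)O)c1-c1ccccc1`, has not yet been measured. Its difference from compound 3 is hydrogen in place of trifluoromethyl on an aromatic carbon. Among the compounds with values here, this is the same kind of change as the one from compound 1 to compound 2, but the surroundings differ: in compound 1 the trifluoromethyl sits meta to a large group and meta to a methoxy group, whereas in compound 3 it sits ortho to a large group. Because the same kind of change gave a 10-fold higher number from compound 1 to compound 2 (1.01 log units; beyond the scatter), a higher number is expected for compound 4, though the changed surroundings make its size uncertain. The expected step is a 3.8-fold higher number from compound 3 to compound 4 (0.59 log units; beyond the scatter). Compound 4 is estimated at 20000 nM in this assay, with a likely range from 7000 nM to 60000 nM.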

Compound 4, half-maximal effective concentration: 3000 nM
Estimate against measurement, compound 4: 6.7-fold (0.82 log units) above; the measured number lies below the stated range.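

In this assay, replacing trifluoromethyl with hydrogen does not have one fixed effect in this series, as the two matched pairs show: the same change on two cores in this assay, a 10-fold higher number (1.01 log units; beyond the scatter) from compound 1 to compound 2 and a 1.7-fold lower number (0.24 log units; within the scatter) from compound 3 to compound 4, 18-fold (1.25 log units) apart, beyond the scatter of two such steps

In the new pair, with the trifluoromethyl ortho to a large group, the result is a 1.7-fold lower number from compound 3 to compound 4 (0.24 log units; within the scatter), so here the group can be removed without a change beyond the usual scatter, and the large step seen on compound 1 cannot be assumed to carry over to another aryl ring. The plain phenyl ring of compound 4 also compares well with the other rings in one case and less well in the other, with a 4.7-fold lower number from compound 2 to compound 4 (0.67 log units; beyond the scatter) and a 2.2-fold higher number from compound 1 to compound 4 (0.34 log units; beyond the scatter), but these two pairs and the steps above show only that the outcome depends on the surrounding ring, not which feature of that ring is responsible or why.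

As far as these compounds go, it remains open how a small group other than trifluoromethyl, such as a chlorine atom or a nitrile, would behave at the same place on the phenyl ring of compound 4. From the compounds shown here alone, it is also open whether the contrast between these two pairs would hold if an amide stood in place of the carboxylic acid shared by all four compounds.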